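The source may hold more compounds than are shown below. What is called first, only, known or untested is meant among the compounds shown, and "the series" means these compounds.

Three compounds have values in an assay on HEK293 cells for displacement of a labelled ligand from 5-hydroxytryptamine receptor 6 (Homo sapiens), read by scintillation counting, with a stated time of 1 h; a lower number here means a stronger inhibitor, a higher number a weaker inhibitor:
compound 1 `C[C@H](NCc1ccc(OCCCCN2CCN(c3cccc4c3ccn4Cc3cccc(Cl)c3)CC2)cc1)C(N)=O` gives 162 nM;
compound 2 `C[C@H](NCc1ccc(OCCCCCN2CCN(c3cccc4c3ccn4Cc3cccc(Cl)c3)CC2)cc1)C(N)=O` gives 232 nM;
compound 3 `C[C@H](NCc1ccc(OCCCCN2CCN(c3cccc4c3ccn4S(=O)(=O)c3ccccc3)CC2)cc1)C(N)=O` gives 68 nM.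

Compound 1 and compound 2 share most of their structure; the difference between the two cores is not broken down here, and their two values lie within the scatter of each other. From compound 1 to compound 3 the change is phenylsulfonyl in place of 3-chlorobenzyl on an aromatic nitrogen, and it gave a 2.4-fold lower number from compound 1 to compound 3 (0.38 log units; beyond the scatter). Compound 4 `C[C@H](NCc1ccc(OCCCCCN2CCN(c3cccc4c3ccn4S(=O)(=O)c3ccccc3)CC2)cc1)C(N)=O` is not yet measured; from compound 2 it differs by phenylsulfonyl in place of 3-chlorobenzyl on an aromatic nitrogen, the same change at the same place. Going by the values given here, a step of similar size is expected from compound 2 to compound 4 in this assay, resting on the one measured step of a 2.4-fold lower number from compound 1 to compound 3 (0.38 log units; beyond the scatter) and on compound 2 standing at 232 nM. For compound 4 the estimate is 100 nM, expected to fall between 50 nM and 200 nM. That estimate for compound 4 means an expected step of a 2.3-fold lower number from compound 2 to compound 4 (0.37 log units; beyond the scatter).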

Compound 4, inhibition constant: 65 nM
Compound 4: the middle estimate sits 1.5-fold (0.19 log units) above what was measured; measured number inside the range.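

In this assay, phenylsulfonyl in place of 3-chlorobenzyl on an aromatic nitrogen gives a 3.6-fold lower number from compound 2 to compound 4 (0.55 log units; beyond the scatter) on the second core. The change therefore carries over from the core of compound 1 to the core of compound 2 in the same direction, and the two steps do not differ in size: the same change on two cores in this assay, a 2.4-fold lower number (0.38 log units; beyond the scatter) from compound 1 to compound 3 and a 3.6-fold lower number (0.55 log units; beyond the scatter) from compound 2 to compound 4, 1.5-fold (0.18 log units) apart, within the scatter of two such steps. Going by these compounds alone, this rests on only two pairs on two closely related cores, so it shows no general rule for the series and does not show what lies behind the step.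

Still open, going by these compounds, is whether the step holds with a shorter chain, or with a carboxylic acid in place of the terminal amide. Also open, on these data alone, is how methylsulfonyl or unsubstituted benzyl on that nitrogen would compare with phenylsulfonyl.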